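This account rests on a few compounds, and the source may have more. Where it says the series, first, only, none or still open, it means among the compounds named here.

Measured compounds:
compound 1 `COc1ccc(/C=C/[C@H]2CC=CC(=O)O2)cc1`, > 100000 nM
compound 2 `O=C1C=CC[C@@H](/C=C/c2ccc(F)cc2)O1`, > 100000 nM
compound 3 `O=C1C=CC[C@H]([C@@H]2C[C@H]2c2ccccc2)O1`, > 100000 nM

In a functional assay on MCF7 cells (Homo sapiens) for antiproliferative activity, read by luminescence and CellTiter-Glo, with a stated time of 48 h (on this read-out lower numbers stand for stronger inhibition and higher numbers for weaker inhibition), compound 1 gives > 100000 nM, which is a limit of the assay and not a number. In this assay compound 2 gives > 100000 nM, again a limit of the assay. In this assay compound 3 gives > 100000 nM, also a limit of the assay. Compound 2 therefore stands at the limit of > 100000 nM in this assay, at which 3 of the 3 values shown sit, and no ordering of compound 1, compound 2 and compound 3 can be read from these numbers. Going by the values given here, no step between measured compounds is available.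

Compound 4 `O=C1C=CC[C@@H](/C=C/c2ccc([N+](=O)[O-])cc2)O1` is the next one to be measured. It differs from compound 2 by nitro in place of fluoro on an aromatic carbon. With every measured value sitting at a limit, there is no evidence on what a change at this position does in this assay. The expected step of a number no higher from compound 2 to compound 4 (the limit leaves the size open) is none beyond the scatter, because compound 2 sits at the limit of > 100000 nM in this assay, at which 3 of the 3 values shown sit, and nothing in the series points to a gain in potency from this change. For compound 4 the estimate in this assay is 100000 nM, in the range 30000 nM to 300000 nM, with a strong chance that the assay again reports only a limit.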

Compound 4, half-maximal inhibitory concentration: > 100000 nM
Compound 4: only a limit was reported (the forecaster's own chance of this, stated with the estimate: 75%); the middle value lies on the limit itself.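

No step from compound 2 to compound 4 can be read in this assay, because both compounds are reported only as a limit of the assay: the limit of > 100000 nM in this assay, at which 4 of the 4 values shown sit.

On these data alone, the effect of nitro in place of fluoro in this assay remains open, as does the concentration at which compound 1, compound 2, compound 3 or compound 4 would reach half-maximal inhibition.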